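Dimethylphenyl in Place of Bromophenyl in Ecdysone Agonists

A few compounds are considered here, and "the series" means these few. Any claim that something is new, unique, unknown or untested is made for them only; others in the source may bear on it.

Compound 1 `CC(C)(C)N(NC(=O)c1ccccc1Br)C(=O)c1ccccc1Cl` carries a 2-bromophenyl group on a carbonyl carbon of the shared core. In an assay on cells for agonist activity at ecdysone receptor (Bombyx mori), read by a luciferase reporter, with a stated time of 24 h (a higher number here means that more compound is needed for the effect, a lower number that less compound is needed), compound 1 gives 316 nM, the highest of the two numbers recorded so far. Compound 2 `Cc1ccc(C(=O)NN(C(=O)c2ccccc2Cl)C(C)(C)C)c(C)c1` differs from it in one place, and in this assay compound 2 gives 162 nM; the step of a 2.0-fold lower number from compound 1 to compound 2 (0.29 log units; within the scatter) lies within the scatter. Compound 3 `Cc1ccc(C(=O)NN(C(=O)c2ccccc2Cl)C(C)(C)C)cc1C` has not yet been measured. It differs from compound 1 as follows: 3,4-dimethylphenyl in place of 2-bromophenyl on a carbonyl carbon. Within the data shown here, the only measured step that bears on this change is a 2.0-fold lower number from compound 1 to compound 2 (0.29 log units; within the scatter), which also exchanged the 2-bromophenyl on a carbonyl carbon for a dimethylphenyl and produced a shift within the scatter. Compound 3 is therefore expected to show a small step, a 1.6-fold lower number from compound 1 to compound 3 (0.20 log units; within the scatter), toward a lower number, one that may well stay within the scatter. Compound 3 is estimated at 200 nM, with a range from 80 nM to 500 nM.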

Compound 3, half-maximal effective concentration: 87.1 nM
Beside the measured number, compound 3's estimate is 2.3-fold (0.36 log units) above it; the measured number falls inside the stated range.
By their numbers in this assay, from the lowest: compounds 3, 2 and 1 (each within the scatter of the next, the first and the last beyond it).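

In this assay, among these compounds, 3,4-dimethylphenyl in place of 2-bromophenyl on a carbonyl carbon gives a 3.6-fold lower number from compound 1 to compound 3 (0.56 log units; beyond the scatter) and is the first exchange at this position that passes the scatter, which the exchange to 2,4-dimethylphenyl in compound 2 did not do. The step between the two dimethylphenyl groups is a 1.9-fold lower number from compound 2 to compound 3 (0.27 log units; within the scatter) and so does not separate compound 2 from compound 3 in this assay. Nothing measured here explains the result for this position.

The compounds shown leave open whether the step from compound 1 to compound 3 follows from the loss of the bromine or from the methyl groups that enter. They also leave open how a single methyl group, a methoxy group, an amine or a carboxylic acid on this ring would read in this assay at this carbonyl carbon.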